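From methoxy to chloro on the shared core

The compounds below may be only part of what the source reports. "The series", "measured", "known", "first", "only" and "open" are said of these compounds alone.

Of the compounds shown here, three with one shared core have been measured in a physicochemical assay for solubility, at pH 6.8; on this read-out lower numbers stand for lower solubility and higher numbers for higher solubility. Compound 1 (`Cc1c(COc2cccc(OCC3CCOCC3)c2)[nH]c2ccccc2c1=O`) carries hydrogen on the aromatic carbon at issue and gives 5000 nM. Compound 2 (`Cc1ccc2[nH]c(COc3cccc(OCC4CCOCC4)c3)c(C)c(=O)c2c1`) carries methyl there and gives < 1000 nM, which is a limit of the assay and not a number. Compound 3 (`COc1ccc2[nH]c(COc3cccc(OCC4CCOCC4)c3)c(C)c(=O)c2c1`) carries methoxy there and gives < 1000 nM, again only a limit. Compound 3 thus stands at the limit of < 1000 nM in this assay, at which 2 of the 3 values shown sit.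

Compound 4 (`Cc1c(COc2cccc(OCC3CCOCC3)c2)[nH]c2ccc(Cl)cc2c1=O`) has chloro in place of methoxy on an aromatic carbon. For the measured compounds named here, three measured steps bear on this change. Methyl in place of hydrogen gave an at least 5.0-fold lower number from compound 1 to compound 2 (0.69 log units; beyond the scatter), and methoxy in place of hydrogen gave an at least 5.0-fold lower number from compound 1 to compound 3 (0.69 log units; beyond the scatter). Methoxy in place of methyl gave a step that the two limits leave unreadable from compound 2 to compound 3, so the one exchange between two substituents on this carbon has no readable size. Compound 4 also keeps a substituent on this carbon, so it is expected to stay with compound 2 and compound 3 rather than return towards compound 1, with no step beyond the scatter in this assay. The estimated change is a step that the limit leaves unreadable from compound 3 to compound 4. Compound 4 is estimated at 700 nM, with an expected range from 250 nM to 2000 nM.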

Compound 4, solubility: < 1000 nM
Compound 4 was reported as a limit (the forecaster's own chance of this, stated with the estimate: 70%); the middle value lies beyond the limit too.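

In this assay, chloro in place of hydrogen gives an at least 5.0-fold lower number from compound 1 to compound 4 (0.69 log units; beyond the scatter), so a third substituent on this aromatic carbon, this one with a single heavy atom and no hydrogen-bond acceptor, joins methyl and methoxy on the same side of compound 1. Compound 4 gives < 1000 nM, which is a limit of the assay and not a number. The steps among compound 2, compound 3 and compound 4 cannot be read, so these three compounds can only be placed together: the limit of < 1000 nM in this assay, at which 3 of the 4 values shown sit.

As far as these compounds go, how far each of the three lies under that limit, and whether they differ from one another at all, stays open. Also open, from the compounds shown here alone, is whether an amine or a carboxylic acid on this carbon would stay with these three or return towards compound 1.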